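A few compounds are considered here, and "the series" means these few. Any claim that something is new, unique, unknown or untested is made for them only; others in the source may bear on it.

Compound 3 `O=c1oc2cccnc2n1CN1CCN(c2ccccc2)CC1` gives 5.9 mg/kg in a functional assay on the whole organism with Mus musculus as the target (on this read-out higher numbers stand for an effect only at larger amounts of compound and lower numbers for an effect already at smaller amounts), and stands second highest among the three measured compounds; its nearest neighbour is compound 1 `O=c1oc2cccnc2n1CN1CCN(c2cccc(C(F)(F)F)c2)CC1` at 3.6 mg/kg, and the furthest is compound 2 `O=c1oc2ccccc2n1CCN1CCN(c2cccc(C(F)(F)F)c2)CC1` at 30.2 mg/kg. Compound 4 `O=c1oc2cccnc2n1CN1CCN(c2cccc(Cl)c2)CC1` differs from compound 3 by chloro in place of hydrogen on an aromatic carbon. Among the compounds with values here, the one measured step that touches this position is a 1.6-fold higher number from compound 1 to compound 3 (0.21 log units; within the scatter), where trifluoromethyl gave way to hydrogen and the number barely moved. Returning a chloro group to the same place is therefore expected to shift this assay little, if at all, beyond the scatter. Compound 4 is expected to give 4.5 mg/kg, with a range from 2.2 mg/kg to 9 mg/kg. The expected step of a 1.3-fold lower number from compound 3 to compound 4 (0.12 log units; within the scatter) is estimated to stay within the scatter.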

Compound 4, dose for half-maximal effect: 10.5 mg/kg
For compound 4 the middle estimate is 2.3-fold (0.37 log units) below the measured one; measured number above the stated range.
By their numbers in this assay, from the lowest: compounds 1, 3 and 4 (each within the scatter of the next, the first and the last beyond it); then compound 2.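

On the aromatic carbon meta to a large group, the choice of substituent now separates two compounds: in this assay, chloro in place of trifluoromethyl gives a modest step beyond the scatter (a 2.9-fold higher number from compound 1 to compound 4 (0.46 log units; beyond the scatter)). Chloro in place of hydrogen stays within the scatter (a 1.8-fold higher number from compound 3 to compound 4 (0.25 log units; within the scatter)), so neither compound 1 nor compound 4 stands apart from compound 3. The compounds shown leave open how a methoxy group, an amine or a carboxylic acid would read at this place. Nothing available accounts for the step from trifluoromethyl to chloro.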